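This account rests on a few compounds, and the source may have more. Where it says the series, first, only, none or still open, it means among the compounds named here.

Measured in an assay on isolated protein with metabotropic glutamate receptor 5 (Rattus norvegicus) as the target; a higher number here means that more compound is needed for the effect, a lower number that less compound is needed:
- compound 1 `O=C(Nc1cc(-c2ccccc2)nn1-c1ccccc1)c1cccc(Cl)c1`: 200 nM
- compound 2 `O=C(Nc1cc(-c2ccccc2)nn1-c1ccccc1)c1cnccn1`: 400 nM
- compound 3 `O=C(Nc1cc(-c2ccccc2)nn1-c1ccccc1)c1ccc(Cl)cc1`: 100 nM

Compound 3 gives the lowest number of the three; its nearest neighbour is compound 1 (a 2.0-fold lower number from compound 1 to compound 3 (0.30 log units; within the scatter)), its furthest compound 2 (a 4.0-fold lower number from compound 2 to compound 3 (0.60 log units; beyond the scatter)). Compound 4 `O=C(Nc1cc(-c2ccccc2)nn1-c1ccccc1)c1ccc(C(F)(F)F)cc1` is the next step: trifluoromethyl in place of chloro on an aromatic carbon. Among the compounds with values here, no measured step changes this substituent; the only steps known swap the whole ring on the carbonyl carbon, a 2.0-fold higher number from compound 1 to compound 2 (0.30 log units; within the scatter) and a 2.0-fold lower number from compound 1 to compound 3 (0.30 log units; within the scatter), and both stay within the scatter. The change from compound 3 to compound 4 is smaller than either of those, so in this assay no step beyond the scatter is expected: a 1.2-fold higher number from compound 3 to compound 4 (0.08 log units; within the scatter) is the estimate. Compound 4 is therefore expected near 120 nM, within 50 nM to 300 nM.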

Compound 4, half-maximal effective concentration: 20 nM
Compound 4: the middle estimate sits 6.0-fold (0.78 log units) above what was measured; measured number outside the range, below it.
By their numbers in this assay, from the lowest: compound 4; then compounds 3, 1 and 2 (each within the scatter of the next, the first and the last beyond it).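

In this assay the substituent itself matters at this position, not only the whole ring on the carbonyl carbon: trifluoromethyl in place of chloro gives a step beyond the scatter (a 5.0-fold lower number from compound 3 to compound 4 (0.70 log units; beyond the scatter)). The 4-(trifluoromethyl)phenyl group also stands clear of the other two rings (a 10-fold lower number from compound 1 to compound 4 (1.00 log units; beyond the scatter)) and (a 20-fold lower number from compound 2 to compound 4 (1.30 log units; beyond the scatter)), so compound 4 gives the lowest number of the four. Nothing measured accounts for this change. Still open, going by these compounds, is whether methyl, methoxy or nitrile at this position would match trifluoromethyl or chloro, and whether trifluoromethyl keeps this number with the substitution pattern of compound 1.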